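Series notes: from compound 2 to compound 3

The source may report more compounds than this note shows. Statements on the series, on what has been measured and on what is new or still open speak of the compounds shown alone.

The series is read in an ADME assay on A-431 cells (Homo sapiens) for cytotoxicity, with a stated time of 48 h; a higher number here means a weaker inhibitor, a lower number a stronger inhibitor. Compound 1 `Cn1c(SCc2ccc(Br)cc2)nnc1-c1cc([N+](=O)[O-])cc([N+](=O)[O-])c1` returns only a limit of the assay, > 30000 nM. Compound 2 `COc1ccc(CSc2nnc(-c3cc([N+](=O)[O-])cc([N+](=O)[O-])c3)n2Cc2ccccc2)cc1` likewise returns only a limit, > 30000 nM. Both values shown sit at the same point, (the limit of > 30000 nM in this assay, at which 2 of the 2 values shown sit), so compound 2 stands level with compound 1 and no number is known for either. Compound 3 `O=[N+]([O-])c1cc(-c2nnc(SCc3ccc(Br)cc3)n2Cc2ccccc2)cc([N+](=O)[O-])c1` is not yet measured in this assay. It differs from compound 2 by bromo in place of methoxy on an aromatic carbon, para to a large group. The same 4-bromobenzyl group is present in compound 1. Within the data shown here, no measured step exists for this change, and with both neighbours at the same point no step beyond the scatter is expected in either direction. The expected step is a number no higher from compound 2 to compound 3 (the limit leaves the size open). Compound 3 is estimated at 30000 nM, with a range from 15000 nM to 100000 nM, and is most likely to be reported again only as a limit.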

Compound 3, half-maximal inhibitory concentration: > 30000 nM
Compound 3 ended at the assay's limit; the forecaster's own chance of this, stated with the estimate: 80%; the middle value sits exactly at the limit.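

No step can be read from compound 1 or compound 2 to compound 3, as all three compounds stand at one point: the limit of > 30000 nM in this assay, at which 3 of the 3 values shown sit.

The compounds shown leave open whether bromo in place of methoxy, or phenyl in place of hydrogen, changes the read-out in this assay at all.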